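Lipophilicity of a methoxypropoxy oxime analogue

A few compounds are considered here, and "the series" means these few. Any claim that something is new, unique, unknown or untested is made for them only; others in the source may bear on it.

Compound 1 `N/N=C/c1c(N)ncnc1Oc1ccc(NC(=O)C2(C(=O)Nc3ccc(F)cc3)CC2)cc1F` is the shared core carrying an amino group on the double-bonded nitrogen. In a physicochemical assay for lipophilicity, using the shake flask method (on this read-out higher numbers stand for higher lipophilicity and lower numbers for lower lipophilicity), compound 1 gives 2.25, the lowest of the three numbers measured. Compound 2 `Nc1ncnc(Oc2ccc(NC(=O)C3(C(=O)Nc4ccc(F)cc4)CC3)cc2F)c1/C=N/OCCO` gives 2.37 in this assay, and the step of a number 0.12 log units higher from compound 1 to compound 2 (within the scatter) lies within the scatter. Compound 3 `C#CCO/N=C/c1c(N)ncnc1Oc1ccc(NC(=O)C2(C(=O)Nc3ccc(F)cc3)CC2)cc1F` gives 3.34, and the step of a number 1.09 log units higher from compound 1 to compound 3 (beyond the scatter) is large; the related step of a number 0.97 log units higher from compound 2 to compound 3 (beyond the scatter) is also beyond the scatter.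

Compound 4 `COCCCO/N=C/c1c(N)ncnc1Oc1ccc(NC(=O)C2(C(=O)Nc3ccc(F)cc3)CC2)cc1F` has not yet been measured. It differs from compound 1 by 3-methoxypropoxy in place of amino on a double-bonded nitrogen. Among the measured compounds shown here, the steps that bear on this change are the two replacements of the same amino group, one by 2-hydroxyethoxy and one by propargyloxy; the first left the number essentially unchanged, the second raised it markedly. The 3-methoxypropoxy group shares the ether linkage of both and brings no hydrogen-bond donor, unlike the hydroxyethoxy group of compound 2, so compound 4 is expected to sit nearer to compound 3 than to compound 2.

The estimate for compound 4 in this assay is 3.4, with a range from 2.9 to 3.9. This estimate corresponds to an expected step of a number 1.15 log units higher from compound 1 to compound 4 (beyond the scatter).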

Compound 4, partition coefficient: 3.18
Estimate against measurement, compound 4: 0.22 log units above, within the range that was stated.
By their numbers in this assay, from the lowest: compounds 1 and 2 (each within the scatter of the next); then compounds 4 and 3 (each within the scatter of the next).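

Replacing amino with 3-methoxypropoxy on a double-bonded nitrogen gives a number 0.93 log units higher from compound 1 to compound 4 (beyond the scatter), so a second chain joined through oxygen at this position also stands clear of the amino compound in this assay. Set against propargyloxy, the same chain gives a number 0.16 log units lower from compound 3 to compound 4 (within the scatter), so in this assay two different chains, one ending in ethynyl and the other in methoxy, cannot be told apart. Against 2-hydroxyethoxy, the change of hydroxy to methoxymethyl gives a number 0.81 log units higher from compound 2 to compound 4 (beyond the scatter), which leaves compound 2 as the only one of the three oxygen-linked chains still within the scatter of compound 1.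

Nothing shown here gives a measured reason for these differences. Compound 2 and compound 4 differ in both chain length and chain end, so the compounds shown do not separate the two, and a 2-methoxyethoxy or 3-hydroxypropoxy chain would speak to that question, while it also stays open where a chain ending in an amine or a carboxylic acid, or one longer than 3-methoxypropoxy, would fall.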